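Amide-side exchange in a series showing no inhibition

This account rests on a few compounds, and the source may have more. Where it says the series, first, only, none or still open, it means among the compounds named here.

Measured so far:
compound 1 `COC[C@@H]1CCCN1C(=O)C1CCCN1c1cc(Nc2cccc(Br)c2)ncn1`, 0%
compound 2 `Cc1cccc(N(C)c2cc(Nc3cccc(C(=O)N(CC(C)C)CC(C)C)c3)ncn2)c1`, 0%
compound 3 `Cc1cccc(Oc2ccnc(N3CCC[C@H]3C(=O)NCCCn3ccnc3)n2)c1`, 0%

In an assay on isolated protein for inhibition of RAC-alpha serine/threonine-protein kinase (Homo sapiens), read by HTRF, tested at 10 uM (on this read-out lower numbers stand for less inhibition and higher numbers for more inhibition at the one concentration tested (going by the name of the read-out)), compound 1 gives 0%. Compound 2 gives 0% in this assay, and compound 3 gives 0%. Among the compounds with values here, the three values are level at the digits reported; no pair lies apart by more than the scatter, so none of the compounds can be ordered against another, and no step between them can be stated. Compound 2 thus stands level with compound 1, its nearest neighbour on the numbers, and with compound 3, the furthest, without any difference that the scatter would let one read.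

Compound 4 `Cc1cccc(N(C)c2cc(Nc3cccc(C(=O)N4CCCC5CCCCC54)c3)ncn2)c1` has not yet been measured in this assay. It differs from compound 2 at one place: a group of 10 heavy atoms (9 carbon, 1 nitrogen; one six-membered non-aromatic ring of carbon only, one six-membered non-aromatic ring with 1 hetero atom) in place of a group of 9 heavy atoms (8 carbon, 1 nitrogen; no ring), on a carbonyl carbon. The exchange sits on a carbonyl carbon whose other neighbours are aromatic carbon. Within the data shown here, no measured pair shows what an exchange at this position does in this assay, so there is nothing to scale a step from, and the three level values offer no higher number to build on. Compound 4 is expected to move no further than the scatter, a number 2 percentage points higher from compound 2 to compound 4 (within the scatter). The estimate for compound 4 is 2%, with a range from -8% to 15%.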

Compound 4, a percentage reported as inhibition, at one concentration (the size of the read-out at that concentration, not a potency): 6%
The estimate for compound 4 lay 4 percentage points below the measured number, and the stated range covers the measured number.
By their numbers in this assay, from the lowest: compounds 1, 2, 3 and 4 (each within the scatter of the next).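

Within the data shown here, the exchange of diisobutylamino for the group with one six-membered non-aromatic ring of carbon only and one six-membered non-aromatic ring with 1 hetero atom, on a carbonyl carbon, gives the first readable step at this position in this assay: a number 6 percentage points higher from compound 2 to compound 4 (within the scatter). The series therefore now holds a direct comparison at this amide side, and it shows that this exchange from a group with no ring to one with two rings, with no hydrogen-bond donors or acceptors and no net charge on either side, leaves the read-out within the scatter. No measurement is available that bears on this result.

A single step leaves open whether this position can affect the read-out at all, or whether any group here would stay level with these values. Piperidine, with only one ring, would separate ring count from group size at this carbonyl carbon, while a group carrying a primary amine or a carboxylic acid would test a substituent of a different kind from both groups compared here.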